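This account rests on a few compounds, and the source may have more. Where it says the series, first, only, none or still open, it means among the compounds named here.

In an assay on HeLa cells for displacement of a labelled ligand from 5-hydroxytryptamine receptor 6 (Homo sapiens) (on this read-out lower numbers stand for stronger inhibition and higher numbers for weaker inhibition), compound 1 `O=S(=O)(c1cccc(Cl)c1)n1ccc2c(N3CCNCC3)cccc21` gives 0.251 nM, the lowest of the two numbers recorded so far. Compound 2 `Cc1cc2c(N3CCNCC3)cccc2n1S(=O)(=O)c1cccc(Cl)c1` gives 0.398 nM in this assay, and a 1.6-fold higher number from compound 1 to compound 2 (0.20 log units; within the scatter) shows that methyl in place of hydrogen on an aromatic carbon leaves the number essentially unchanged. Compound 3 `N#Cc1ccc2c(ccn2S(=O)(=O)c2cccc(Cl)c2)c1N1CCNCC1` is the unmeasured member; it differs from compound 1 by cyano in place of hydrogen on an aromatic carbon. Within the data shown here, no measured step involves a cyano group, so the only guide is the step from compound 1 to compound 2, which stayed within the scatter for a different small change on the shared core. On that basis the step from compound 1 to compound 3 in this assay is expected to be small, a 2.0-fold higher number from compound 1 to compound 3 (0.30 log units; within the scatter), with at most a slight lean toward a higher number. Compound 3 is accordingly estimated to give 0.5 nM in this assay, within a range from 0.15 nM to 2 nM.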

Compound 3, inhibition constant: 5.01 nM
Compound 3: middle estimate off by 10-fold (1.00 log units), on the low side; measured number above the stated range.
By their numbers in this assay, from the lowest: compounds 1 and 2 (each within the scatter of the next); then compound 3.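

Among these compounds, the step of a 20-fold higher number from compound 1 to compound 3 (1.30 log units; beyond the scatter) in this assay is the first one beyond the scatter, and it comes from cyano on the six-membered aromatic ring, ortho to the piperazin-1-yl group. The shared core therefore does not tolerate every small change alike, as the earlier step of a 1.6-fold higher number from compound 1 to compound 2 (0.20 log units; within the scatter) alone might have suggested. That methyl differs from cyano in both the group and its place, however, so the two steps cannot separate the role of the group from that of the position, and no measurement at hand explains the higher number.

The compounds shown leave open whether fluorine, a methoxy group or a primary amide on this same carbon would raise the number as much as cyano does. They also leave open how cyano would read on the carbon that carries the methyl in compound 2.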